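Ethyl on the Shared Core and Expected Clearance

The source may report more compounds than this note shows. Statements on the series, on what has been measured and on what is new or still open speak of the compounds shown alone.

compound 1 `O=C1c2ccc(Cl)cc2CN1c1cccnc1`: 76.5 mL/min/kg
compound 2 `CCC1c2cc(Cl)ccc2C(=O)N1c1cccnc1`: 65.9 mL/min/kg
compound 3 `CCC(=O)N[C@@H]1CCCc2c1cncc2N1Cc2cc(Cl)ccc2C1=O`: < 20.2 mL/min/kg

In an ADME assay on microsomes from liver (Mus musculus) for metabolic stability, read by LC-MS, using NADPH, with stated times of 10 min and 30 min (a higher number here means faster removal of the compound, a lower number slower removal), compound 1 and compound 2 both give a number. For compound 3 the read-out is the limit of < 20.2 mL/min/kg in this assay, at which 1 of the 3 values shown sits, a limit rather than a number. From compound 1 to compound 2 the change is ethyl in place of hydrogen on a saturated ring carbon, and this gave a 1.2-fold lower number from compound 1 to compound 2 (0.06 log units; within the scatter). Compound 4 `CCC(=O)N[C@@H]1CCCc2c1cncc2N1C(=O)c2ccc(Cl)cc2[C@H]1CC` arises from compound 3 by the same kind of change, (ethyl in place of hydrogen on a saturated ring carbon); the surroundings differ only in that the ring atom it is next to bears a pyridin-3-yl group in one case and a large group in the other. The difference between the two cores is not broken down here. Because a 1.2-fold lower number from compound 1 to compound 2 (0.06 log units; within the scatter) stayed within the scatter, the step to compound 4 is expected to be a step that the limit leaves unreadable from compound 3 to compound 4. Compound 4 is thus estimated at 15 mL/min/kg, between 7 mL/min/kg and 32 mL/min/kg, and may again give only a limit.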

Compound 4, clearance: 44.9 mL/min/kg
Compound 4: the middle estimate sits 3.0-fold (0.48 log units) below what was measured; measured number above the stated range.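

In this assay, ethyl in place of hydrogen on a saturated ring carbon gives an at least 2.2-fold higher number from compound 3 to compound 4 (0.34 log units; beyond the scatter), so on this core the change goes with faster removal, whereas on the core of compound 1 it stayed within the scatter. This does not show that the two cores truly respond differently: the same change on two cores in this assay, a 1.2-fold lower number (0.06 log units; within the scatter) from compound 1 to compound 2 and an at least 2.2-fold higher number (0.34 log units; beyond the scatter) from compound 3 to compound 4; the limit leaves it open whether they differ. From the compounds shown here alone, compound 3 has a limit and not a number, so the exact size of its step remains unknown: the limit of < 20.2 mL/min/kg in this assay, at which 1 of the 4 values shown sits.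

The compounds shown leave open how methyl or a longer chain such as propyl would behave at this ring carbon on either core. They also leave open which of the parts that separate the two cores matters for this change.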